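From 2-acetylethyl to bromo on the shared core

This account rests on a few compounds, and the source may have more. Where it says the series, first, only, none or still open, it means among the compounds named here.

In a functional assay on HT-29 cells (Homo sapiens) for cytotoxicity, read by MTT assay (on this read-out lower numbers stand for stronger inhibition and higher numbers for weaker inhibition), compound 1 (`CC(=O)CC[C@]1(C(C)=O)C(=O)O[C@@H](OC(C)=O)[C@H]1C`) gives 7000 nM as its reading. Compound 2 (`CC(=O)O[C@@H]1OC(=O)[C@](OC(=O)c2ccccc2)(C(C)=O)[C@@H]1C`) gives 8000 nM in this assay and lies within the scatter of compound 1, so the two numbers set no order between them.

Compound 3 (`CC(=O)O[C@@H]1OC(=O)[C@](Br)(C(C)=O)[C@@H]1C`) still awaits measurement. It carries bromo in place of 2-acetylethyl on a saturated ring carbon. Among the compounds with values here, no measured step shows what this exchange does, so the forecast is loose and rests only on the close values of compound 1 and compound 2. The expected change a 1.4-fold lower number from compound 1 to compound 3 (0.15 log units; within the scatter) is estimated to stay within the scatter, leaning only slightly towards a lower number. For compound 3 the estimated value is 5000 nM with an expected range from 1500 nM to 15000 nM in this measurement.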

Compound 3, half-maximal inhibitory concentration: 12000 nM
Compound 3: the middle estimate sits 2.4-fold (0.38 log units) below what was measured, and the stated range covers the measured number.
By their numbers in this assay, from the lowest: compounds 1, 2 and 3 (each within the scatter of the next).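

In this assay the step (a 1.7-fold higher number from compound 1 to compound 3 (0.23 log units; within the scatter)) lies within the scatter, with bromo in place of 2-acetylethyl on a saturated ring carbon. Within the data shown here, this is the first direct comparison at this position: a chain of 5 heavy atoms with one double bond and one hydrogen-bond acceptor gives way to a single bromine atom, and the readings of compound 1 and compound 3 cannot be told apart. Nothing measured on these compounds offers an explanation for this result.

On these data alone, what an amine, a carboxylic acid or a chain longer than 2-acetylethyl would read at this saturated ring carbon stays open. As far as these compounds go, whether any group at this carbon can move the number beyond the scatter stays open as well.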